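The source may report more compounds than this note shows. Statements on the series, on what has been measured and on what is new or still open speak of the compounds shown alone.

Within the data shown here, in an assay on isolated protein for inhibition of ubiquitin carboxyl-terminal hydrolase 7 (Homo sapiens), with stated times of 30 min and 2 h (a lower number here means a stronger inhibitor, a higher number a weaker inhibitor), compound 3 `Cn1nc2c(=O)n(CC3(O)CCN(Cc4ccc(-c5cccs5)cc4Cl)CC3)cnc2c1-c1ccc(CN)cc1` gives 38.6 nM, the lowest of the three numbers measured so far; compound 1 `Cn1nc2c(=O)n(CC3(O)CCN(Cc4ccc(-c5cnco5)cc4Cl)CC3)cnc2c1-c1ccc(CN)cc1` gives 71.6 nM, and compound 2 `Cn1nc2c(=O)n(CC3(O)CCN(Cc4ccc(-n5cccn5)cc4Cl)CC3)cnc2c1-c1ccc(CN)cc1` gives 233 nM. The step of a 1.9-fold lower number from compound 1 to compound 3 (0.27 log units; within the scatter) lies within the scatter, while a 6.0-fold lower number from compound 2 to compound 3 (0.78 log units; beyond the scatter) lies beyond it. Compound 4 `Cn1nc2c(=O)n(CC3(O)CCN(Cc4ccc(-c5ccsc5)cc4Cl)CC3)cnc2c1-c1ccc(CN)cc1` differs from compound 3 in one place: thiophen-3-yl in place of thiophen-2-yl on an aromatic carbon. Among the measured compounds shown here, no measured step exchanges thiophen-2-yl for thiophen-3-yl; the steps that end in compound 3 each replace a different group by thiophen-2-yl, and only a 3.3-fold higher number from compound 1 to compound 2 (0.51 log units; beyond the scatter) and a 6.0-fold lower number from compound 2 to compound 3 (0.78 log units; beyond the scatter) were beyond the scatter. The expected step of a 1.3-fold higher number from compound 3 to compound 4 (0.11 log units; within the scatter) is therefore small, with no direction predicted beyond the scatter. Compound 4 is expected to give 50 nM, with a range from 20 nM to 125 nM, in this assay.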

Compound 4, half-maximal inhibitory concentration: 59.5 nM
Estimate against measurement, compound 4: 1.2-fold (0.08 log units) below, and the stated range covers the measured number.
By their numbers in this assay, from the lowest: compounds 3, 4 and 1 (each within the scatter of the next); then compound 2.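

In this assay the step of a 1.5-fold higher number from compound 3 to compound 4 (0.19 log units; within the scatter) shows that, on this ring para to a large group, the two points of attachment of the thiophene are not told apart. With a 3.9-fold lower number from compound 2 to compound 4 (0.59 log units; beyond the scatter) as well, thiophen-3-yl, like thiophen-2-yl, stands clear of 1H-pyrazol-1-yl. The step of a 1.2-fold lower number from compound 1 to compound 4 (0.08 log units; within the scatter) leaves it level with 1,3-oxazol-5-yl. Going by these compounds, whether a phenyl ring, an amine or a carboxylic acid would be tolerated at this position stays open. Nothing available explains the difference between these rings.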